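Swapping fluoro for methoxy beside the sulfonamide

The source may report more compounds than this note shows. Statements on the series, on what has been measured and on what is new or still open speak of the compounds shown alone.

Of the compounds shown here, three that share a common core have been measured in a functional assay on CHO cells for antagonist activity at transient receptor potential cation channel subfamily V member 1 (Rattus norvegicus); a lower number here means a stronger inhibitor, a higher number a weaker inhibitor. Compound 1 `CC(C)(C)c1ccc(CNC(=S)NC(c2ccccc2)c2ccc(NS(C)(=O)=O)c(F)c2)cc1` gives 860 nM. Compound 2 `CC(C)(C)c1ccc(CNC(=S)NC2(c3ccc(NS(C)(=O)=O)cc3)CC2)cc1` gives 60 nM. Compound 3 `CC(C)(C)c1ccc(CNC(=S)NC(C)(C)c2ccc(NS(C)(=O)=O)c(F)c2)cc1` gives 980 nM, which is the highest of the three numbers, meaning the weakest inhibition observed so far. The gap between compound 3 and compound 1 lies within the scatter of the assay, so those two cannot be told apart. Compound 2, by contrast, sits well beyond the scatter, with a number far below that of compound 3.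

Compound 4 `COc1cc(C(C)(C)NC(=S)NCc2ccc(C(C)(C)C)cc2)ccc1NS(C)(=O)=O` has not yet been measured. It differs from compound 3 in a single spot: methoxy in place of fluoro on an aromatic carbon. For the measured compounds named here, no measured pair in this set shows this same swap, so there is no direct precedent for how large a step to expect.

Given that lack, the most cautious expectation is a small step in this assay, in either direction and quite possibly not beyond the usual scatter. The step from compound 3 to compound 4 is expected to be a 1.2-fold lower number from compound 3 to compound 4 (0.09 log units; within the scatter). Compound 4 is therefore estimated at 800 nM, with a plausible range from 250 nM to 3000 nM.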

Compound 4, inhibition constant: 663 nM
Beside the measured number, compound 4's estimate is 1.2-fold (0.08 log units) above it, and the stated range covers the measured number.
By their numbers in this assay, from the lowest: compound 2; then compounds 4, 1 and 3 (each within the scatter of the next).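

In this assay, putting methoxy in place of fluoro on the aromatic carbon ortho to the methanesulfonamido group gives a 1.5-fold lower number from compound 3 to compound 4 (0.17 log units; within the scatter), so the two compounds cannot be told apart. For the compounds shown here, this is the first pair in the set that differs in only one place, and it gives a direct reading that was missing before: at this position, the change from fluoro to methoxy, which adds a hydrogen-bond acceptor and one more heavy atom, produces no step that stands out from the usual variation between repeated measurements. No measurement is available that would explain this result.

The compounds shown leave open what a longer chain such as ethoxy, or an amine, would do at this same position, since a single swap cannot show how much variety the position allows. Also open, going by these compounds, is whether the step from fluoro to methoxy would stay as small on the core of compound 1, which carries fluoro on the same aromatic carbon.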